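This account rests on a few compounds, and the source may have more. Where it says the series, first, only, none or still open, it means among the compounds named here.

Measured so far in a functional assay on Jurkat cells (Homo sapiens) for cytotoxicity, with a stated time of 72 h; a lower number here means that less compound is needed, a higher number that more compound is needed for the effect:
- compound 1 `C=C[C@@](C)(/C=C/c1ccc(OCc2ccccc2)cc1)CCC=C(C)C`: > 49000 nM
- compound 2 `C=C[C@@](C)(/C=C/c1ccc(O)c(/C=C/C(=O)c2ccccc2)c1)CCC=C(C)C`: > 49000 nM

The two compounds share one reading, (the limit of > 49000 nM in this assay, at which 2 of the 2 values shown sit). Compound 2 gives > 49000 nM, and this is a limit of the assay, not a number. Compound 1 gives > 49000 nM, which is likewise only a limit. Going by the values given here, no number has therefore been obtained, and no measured step is available as a guide.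

Compound 3 `C=C[C@@](C)(/C=C/c1ccc(O)c(/C=C/c2ccc(F)cc2)c1)CCC=C(C)C` keeps most of compound 2 and differs in one place: 4-fluorophenyl in place of benzoyl on a double-bonded chain carbon bound to a double-bonded chain carbon.

In this assay, no step beyond the scatter is expected, although any number that does appear would be expected to lie on the lower side. This expectation rests on compound 2 and its reading of > 49000 nM, which is a limit. The expected change is an at least 1.4-fold lower number from compound 2 to compound 3 (0.14 log units; that floor lies within the scatter). For compound 3 the estimated value is 35000 nM, with an expected range of 12000 nM to 60000 nM.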

Compound 3, half-maximal effective concentration: > 49000 nM
Compound 3 ended at the assay's limit; the forecaster's own chance of this, stated with the estimate: 50%; at least 1.4-fold (0.14 log units) between middle value and limit.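

In this assay compound 3 gives > 49000 nM as a limit, not a number. Compound 2 also stands at a limit, so no step can be read between compound 2 and compound 3: the limit of > 49000 nM in this assay, at which 3 of the 3 values shown sit.

Still open, as far as these compounds go, is whether exchanging benzoyl for 4-fluorophenyl changes the reading in this assay at all, since the series has yielded no number so far.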